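This account rests on a few compounds, and the source may have more. Where it says the series, first, only, none or still open, it means among the compounds named here.

Measured so far:
Compound 1 `CN(C(=N)Nc1cccc2ccccc12)c1cccc([N+](=O)[O-])c1` — 6260 nM
Compound 2 `CN(C(=N)Nc1cccc2ccccc12)c1cccc(N=[N+]=[N-])c1` — 3020 nM

Of the compounds shown here, two sharing one core have been measured in an assay on membranes from brain (Cavia porcellus) for binding affinity to Sigma non-opioid intracellular receptor 1 (Homo sapiens), read by radioligand binding; a higher number here means a weaker inhibitor, a lower number a stronger inhibitor. Compound 1 gives 6260 nM, and compound 2 gives 3020 nM. Going by the values given here, of the two numbers, compound 2 stands at the lower one, its nearest neighbour being compound 1; the one step between them, a 2.1-fold lower number from compound 1 to compound 2 (0.32 log units; beyond the scatter), is modest yet beyond the scatter.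

Compound 3 `CN(C(=N)Nc1cccc2ccccc12)c1ccccc1` has not yet been measured in this assay. It differs from compound 2 by hydrogen in place of azido on an aromatic carbon. Among the compounds with values here, the only measured step that bears on this change is a 2.1-fold lower number from compound 1 to compound 2 (0.32 log units; beyond the scatter), which concerned the same position on the ring, meta to a large group, but exchanged one group for another rather than removing one; it is the sole guide available. Given that small single step, the step from compound 2 to compound 3 is not expected to be large, and its direction is uncertain. The step is estimated as a 1.2-fold lower number from compound 2 to compound 3 (0.08 log units; within the scatter). Compound 3 is therefore expected to give about 2500 nM, within a range of 800 nM to 8000 nM.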

Compound 3, half-maximal inhibitory concentration: 2900 nM
The estimate for compound 3 lay 1.2-fold (0.06 log units) below the measured number; the range from low to high includes it.
By their numbers in this assay, from the lowest: compounds 3 and 2 (each within the scatter of the next); then compound 1.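

In this assay, hydrogen in place of azido on this aromatic carbon, meta to a large group, makes no difference beyond the scatter, with a 1.0-fold lower number from compound 2 to compound 3 (0.02 log units; within the scatter). The compound carrying hydrogen gives the reference that the earlier pair lacked, and against it nitro is the group that stands apart, with a 2.2-fold lower number from compound 1 to compound 3 (0.33 log units; beyond the scatter), so at this position the azido and hydrogen compounds cannot be told apart and only the nitro compound gives a higher number. No evidence is available on what lies behind this difference between nitro and the other two groups.

Going by these compounds, whether an amine, a methoxy group or a chlorine atom at this position would read with hydrogen and azido or with nitro remains open, as does whether the same three groups would give the same picture on another carbon of this ring. On these data alone, the three compounds also differ at this one place only, so how the numbers respond to a change elsewhere in the shared core is still unknown.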